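The source may hold more compounds than are shown below. What is called first, only, known or untested is meant among the compounds shown, and "the series" means these compounds.

Measured compounds in the series:

- compound 1, `CCCNC(=O)NCCC(O)c1ccccc1N`: 19%
- compound 2, `Nc1ccccc1C(O)CCNC(=O)Nc1ccccc1`: 27.9%
- compound 3, `CCCNC(=O)NCCC(O)c1cc(Cl)ccc1N`: 19.6%

All three have been run in an assay for inhibition of Nitric oxide synthase, inducible (Homo sapiens), read by scintillation counting, with a stated time of 30 min, tested at 1 mM; on this read-out higher numbers stand for more inhibition at the one concentration tested (going by the name of the read-out) and lower numbers for less inhibition. In this assay compound 1 gives 19%, compound 2 gives 27.9% and compound 3 gives 19.6%. The step of a number 8.9 percentage points higher from compound 1 to compound 2 (within the scatter) follows from the change (phenyl in place of propyl on an amide-type nitrogen). The step of a number 0.6 percentage points higher from compound 1 to compound 3 (within the scatter) follows from the change (chloro in place of hydrogen on an aromatic carbon); compound 3 and compound 1 are therefore not ordered against each other, and compound 2 is likewise within the scatter of both.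

Compound 4, `Nc1ccc(Cl)cc1C(O)CCNC(=O)Nc1ccccc1`, has not yet been measured in this assay. It differs from compound 3 by phenyl in place of propyl on an amide-type nitrogen. The same change, from propyl to phenyl on the amide-type nitrogen, has already been made once, from compound 1 to compound 2, where it gave a number 8.9 percentage points higher from compound 1 to compound 2 (within the scatter). The cores of the two pairs differ by chloro in place of hydrogen on an aromatic carbon, the chloro sitting on the aromatic carbon described there; the place of the propyl-to-phenyl change is word for word the same in both pairs, so the change is the same, only the core carrying it differs.

The step from compound 3 to compound 4 is therefore expected to be of the same order as the earlier one, a number 8.4 percentage points higher from compound 3 to compound 4 (within the scatter), resting on a number 8.9 percentage points higher from compound 1 to compound 2 (within the scatter) and on the small step of a number 0.6 percentage points higher from compound 1 to compound 3 (within the scatter), which shows the chloro on its own leaving the read-out essentially unchanged. For compound 4 the estimate in this assay is 28%, with a range from 14% to 42%; the basis is one prior pair only and the expected step lies within the scatter.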

Compound 4, a percentage reported as inhibition, at one concentration (the size of the read-out at that concentration, not a potency): 3.11%
Compound 4: the middle estimate sits 24.9 percentage points above what was measured; the whole stated range lies above it.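

In this assay, phenyl in place of propyl on the amide-type nitrogen gives a number 16.5 percentage points lower from compound 3 to compound 4 (beyond the scatter), so the step seen on the core of compound 1 does not carry over to the chloro-bearing core: the same change on two cores in this assay, a number 8.9 percentage points higher (within the scatter) from compound 1 to compound 2 and a number 16.5 percentage points lower (beyond the scatter) from compound 3 to compound 4, 25.4 percentage points apart, beyond the scatter of two such steps. Read along the other edge of the same set of compounds, chloro in place of hydrogen on an aromatic carbon gives a number 24.8 percentage points lower from compound 2 to compound 4 (beyond the scatter), so the chloro has no fixed contribution either and its outcome differs with the group on the amide-type nitrogen: the same change on two cores in this assay, a number 0.6 percentage points higher (within the scatter) from compound 1 to compound 3 and a number 24.8 percentage points lower (beyond the scatter) from compound 2 to compound 4, 25.4 percentage points apart, beyond the scatter of two such steps. This shows that, for these compounds, the two changes do not add up and a step taken from one core is a poor guide on the other, but it does not show why, and it rests on a single set of four compounds, each read at one concentration, which gives no potency.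

From the compounds shown here alone, it remains open whether the low number of compound 4 is particular to the combination of chloro and phenyl or would also appear with a benzyl or a butyl group on the amide-type nitrogen. Going by these compounds, it is equally open whether fluoro or methyl in place of the chloro would give the same departure from the step seen on the core of compound 1.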